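Methoxyphenyl for bromophenyl on a benzofuran thiazolidinone

This account rests on a few compounds, and the source may have more. Where it says the series, first, only, none or still open, it means among the compounds named here.

In a functional assay on A549 cells (Homo sapiens) for antiproliferative activity, read by MTT assay, with a stated time of 96 h (on this read-out lower numbers stand for stronger inhibition and higher numbers for weaker inhibition), compound 2 `COC(=O)/C=C1/SC(N2N=C(c3cc4ccccc4o3)CC2c2cccc(Br)c2)=NC1=O` gives 4.29 ug/mL, the highest of the two numbers recorded so far; compound 1 `CCOC(=O)/C=C1/SC(N2N=C(c3cc4ccccc4o3)CC2c2ccc(OC)cc2)=NC1=O` gives 1.21 ug/mL, a lower number beyond the scatter. Compound 3 `COC(=O)/C=C1/SC(N2N=C(c3cc4ccccc4o3)CC2c2ccc(OC)cc2)=NC1=O` carries the change (4-methoxyphenyl in place of 3-bromophenyl on a saturated ring carbon), and compound 1 also bears 4-methoxyphenyl. Because compound 1 reaches 1.21 ug/mL in this assay, compound 3 is expected to follow with a step from compound 2 a 2.9-fold lower number from compound 2 to compound 3 (0.46 log units; beyond the scatter) toward a lower number. Compound 3 is therefore estimated at 1.5 ug/mL, within a range of 0.7 ug/mL to 3.5 ug/mL.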

Compound 3, half-maximal inhibitory concentration: 2.45 ug/mL
Estimate against measurement, compound 3: 1.6-fold (0.21 log units) below, and the stated range covers the measured number.
By their numbers in this assay, from the lowest: compound 1; then compounds 3 and 2 (each within the scatter of the next).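

In this assay, 4-methoxyphenyl in place of 3-bromophenyl on the saturated ring carbon gives a 1.8-fold lower number from compound 2 to compound 3 (0.24 log units; within the scatter) and so does not separate the two groups. Hydrogen in place of methyl on the saturated chain carbon bound to an oxygen next to a carbonyl group gives a 2.0-fold higher number from compound 1 to compound 3 (0.31 log units; beyond the scatter) as a modest step, so the change at the chain moves the number beyond the scatter where the ring-carbon change does not. No measured evidence speaks to the reason for either step. The compounds shown leave open how a 3-methoxyphenyl or 4-bromophenyl group would read on the ring carbon, and whether a longer chain such as propyl would extend the step at the chain.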